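The source may hold more compounds than are shown below. What is called first, only, known or untested is meant among the compounds shown, and "the series" means these compounds.

Of the compounds shown here, three have been measured so far in a functional assay for agonist activity at Free fatty acid receptor 1 (Homo sapiens), read by FLIPR, in the presence of a further agent that is not named here; on this read-out lower numbers stand for an effect already at smaller amounts and higher numbers for an effect only at larger amounts of compound. Compound 1, `Cc1cc(Oc2ccc(CC3SC(=O)NC3=O)cc2)nc(C(F)(F)F)c1`, gives 688 nM. Compound 2, `O=C1NC(=O)C(Cc2ccc(Oc3cccc(C(F)(F)F)n3)cc2)S1`, gives 1640 nM. These two differ only by hydrogen in place of methyl on an aromatic carbon, and that change produced a 2.4-fold higher number from compound 1 to compound 2 (0.38 log units; beyond the scatter). Compound 3, `Cc1cc(C)cc(Oc2ccc(CC3SC(=O)NC3=O)cc2)c1`, gives 96 nM, the lowest number of the three; the difference between the core of compound 3 and the core of compound 1 is not broken down here.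

Compound 4, `Cc1cccc(Oc2ccc(CC3SC(=O)NC3=O)cc2)c1`, has not yet been measured in this assay. It differs from compound 3 by hydrogen in place of methyl on an aromatic carbon. This is the same kind of change as that from compound 1 to compound 2, but the surroundings differ: in the earlier pair the ring carried one nitrogen and the change was meta to a trifluoromethyl group and opposite the ring nitrogen, whereas here the ring is of carbon only and the change is meta to a methyl group.

For compound 4 the step of a 2.1-fold higher number from compound 3 to compound 4 (0.32 log units; beyond the scatter) is expected, because a 2.4-fold higher number from compound 1 to compound 2 (0.38 log units; beyond the scatter) was the result of the same kind of change. Compound 4 is therefore estimated at about 200 nM, most likely between 100 nM and 450 nM.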

Compound 4, half-maximal effective concentration: 203 nM
For compound 4 the middle estimate is 1.0-fold (0.01 log units) below the measured one, within the range that was stated.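

Taking away the methyl group behaves much the same on both cores in this assay. The new pair gives a 2.1-fold higher number from compound 3 to compound 4 (0.33 log units; beyond the scatter), and set beside the earlier pair the two steps agree: the same change on two cores in this assay, a 2.4-fold higher number (0.38 log units; beyond the scatter) from compound 1 to compound 2 and a 2.1-fold higher number (0.33 log units; beyond the scatter) from compound 3 to compound 4, 1.1-fold (0.05 log units) apart, within the scatter of two such steps. So the swap of methyl for hydrogen carried over at about the same size, even though one ring holds a nitrogen and the other is of carbon only, but two pairs are a small sample, and they show neither why the number rises nor that it would rise the same way on a further core.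

The compounds shown have only hydrogen or methyl at this place, so it stays open how an ethyl group, a methoxy group or a chlorine atom would behave there. Also open, going by these compounds, is whether a ring nitrogen or a trifluoromethyl group on its own, each placed on the core of compound 4, would shift the number.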